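Ring amine in place of a dimethylamino on the core

The compounds below may be only part of what the source reports. "The series", "measured", "known", "first", "only" and "open" are said of these compounds alone.

Three amides on a shared core have been measured in an assay on isolated protein for inhibition of Ectonucleotide pyrophosphatase/phosphodiesterase family member 1 (Homo sapiens), tested at 10 uM; on this read-out higher numbers stand for more inhibition at the one concentration tested (going by the name of the read-out) and lower numbers for less inhibition. Compound 1 `COc1ccc(NC(=O)CSc2nc3ccc(N(C)C)nc3[nH]2)cc1OC` gives 58%, the highest of the three numbers, although neither of the others is separated from it beyond the usual scatter. Among the measured compounds shown here, compound 2 `CC(=O)c1cccc(NC(=O)CSc2nc3cccnc3[nH]2)c1` gives 50% in this assay, and compound 3 `COc1ccc(NC(=O)CSc2nc3cccnc3[nH]2)cc1` gives 48%; no step between any pair of these measured compounds has been worked out, so only their values stand side by side. Compound 4 `COc1ccc(NC(=O)CSc2nc3ccc(N4CCCCC4)nc3[nH]2)cc1OC` has not yet been measured. It differs from compound 1 in one place: piperidin-1-yl in place of dimethylamino on an aromatic carbon. For the measured compounds named here, no measured step of this kind is available, so the change is expected to shift this assay only slightly, if at all, with a small rise as likely as none. Compound 4 is therefore estimated at 60%, within a range of 40% to 80%. The expected step is a number 2 percentage points higher from compound 1 to compound 4 (within the scatter).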

Compound 4, a percentage reported as inhibition, at one concentration (the size of the read-out at that concentration, not a potency): 27%
Compound 4: the middle estimate sits 33 percentage points above what was measured, outside the stated range (below it).
By their numbers in this assay, from the lowest: compound 4; then compounds 3, 2 and 1 (each within the scatter of the next).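

In this assay, the position next to the ring nitrogen does not treat these two amines alike: piperidin-1-yl in place of dimethylamino gives a number 31 percentage points lower from compound 1 to compound 4 (beyond the scatter) on this otherwise unchanged compound. The size of the amine at this aromatic carbon therefore matters, although this single step cannot separate the ring from the added carbons. No available evidence bears on the cause of this loss. Open, on these data alone, is whether pyrrolidin-1-yl, morpholin-4-yl or diethylamino at this carbon stays with compound 1 or falls with compound 4. Also open, as far as these compounds go, is whether an unsubstituted amino group would change the read-out at all.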